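A Single Methoxy Added to Compound 2

A few compounds are considered here, and "the series" means these few. Any claim that something is new, unique, unknown or untested is made for them only; others in the source may bear on it.

Of the compounds shown here, two have been measured in a functional assay on A498 cells (Homo sapiens) for inhibition; a higher number here means a weaker inhibitor of growth, a lower number a stronger inhibitor of growth. Compound 1 `O=C(/C=C/c1cccc(O)c1)c1cccc(-n2cc(-c3ccc(Cl)cc3)[nH]c2=O)c1` gives 3710 nM. Compound 2 `COc1cc(/C=C/C(=O)c2cccc(-n3cc(-c4ccccc4)[nH]c3=O)c2)cc(OC)c1OC` gives 2650 nM in this assay. Compound 2 thus has the lower of the two numbers, but the gap to compound 1 lies within the scatter, so the two cannot be ranked against each other. Within the data shown here, they also differ in more than one place, so no single step joins them, and their two values can only be read side by side.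

Compound 3 `COc1ccc(-c2cn(-c3cccc(C(=O)/C=C/c4cc(OC)c(OC)c(OC)c4)c3)c(=O)[nH]2)cc1` has not yet been measured. It differs from compound 2 in one place: methoxy in place of hydrogen on an aromatic carbon, or in words, methoxy in place of hydrogen on an aromatic carbon. The measured pair offers no step of this kind to lean on, and a change this small, on the outer ring of the molecule, gives no reason to expect a large shift. The step from compound 2 to compound 3 is therefore expected to be a 1.1-fold lower number from compound 2 to compound 3 (0.03 log units; within the scatter), nothing beyond the scatter. Compound 3 is expected to give about 2500 nM in this assay, within a likely range from 1000 nM to 6500 nM.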

Compound 3, concentration for 50% growth inhibition: 4210 nM
Compound 3: the middle estimate sits 1.7-fold (0.23 log units) below what was measured; the range from low to high includes it.
By their numbers in this assay, from the lowest: compounds 2, 1 and 3 (each within the scatter of the next).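

In this assay, among these compounds, the only single-place step so far reads a 1.6-fold higher number from compound 2 to compound 3 (0.20 log units; within the scatter), so the change from phenyl to 4-methoxyphenyl gives two compounds whose values cannot be told apart. Among the compounds shown here, this is the first direct look at this position, on an aromatic carbon para to a large group, and it shows that a methoxy group there, with its 2 heavy atoms and 1 hydrogen-bond acceptor, makes no difference that stands clear of the usual scatter of repeated measurements. No measurement shown here offers an explanation for how close the two values lie.

A single step with a single group cannot show whether this position would respond to any other group, such as an amine, a carboxylic acid or a longer chain like butoxy, so its tolerance remains an observation about methoxy alone. Compound 1 carries a chlorine at the same position but also differs elsewhere, which leaves open whether chlorine on its own would behave like methoxy there.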